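An aryl exchange on the ring nitrogen

A few compounds are considered here, and "the series" means these few. Any claim that something is new, unique, unknown or untested is made for them only; others in the source may bear on it.

Compound 1, `CN(C)/C=N/c1c(C=O)c(-c2ccccc2)nn1-c1ccccc1Cl`, gives 23300 nM in a functional assay on NPC-TW01 cells (Homo sapiens) for inhibition, read by MTT assay, with a stated time of 72 h; a higher number here means a weaker inhibitor of growth, a lower number a stronger inhibitor of growth.
Compound 2, `Cc1cccc(-n2nc(-c3ccccc3)c(C=O)c2/N=C/N(C)C)c1`, gives 8900 nM in this assay.
Compound 3, `CN(C)/C=N/c1c(C=O)c(-c2ccccc2)nn1-c1cccc([N+](=O)[O-])c1`, gives 36700 nM in this assay.

Among the three measured compounds, compound 3 has the highest number in this assay; its gap to compound 1 is within the scatter, while its gap to compound 2 is beyond it. Compound 4, `COc1ccc(-n2nc(-c3ccccc3)c(C=O)c2/N=C/N(C)C)cc1`, has not been measured. It differs from compound 3 by 4-methoxyphenyl in place of 3-nitrophenyl on an aromatic nitrogen. The most relevant measured step is a 4.1-fold higher number from compound 2 to compound 3 (0.62 log units; beyond the scatter), which shows that a nitro in place of a methyl on the aryl group went with a clearly higher number; a 1.6-fold higher number from compound 1 to compound 3 (0.20 log units; within the scatter) stayed within the scatter. Among the measured compounds shown here, compound 4 removes the nitro and brings in a methoxy, though at a different position than the methyl of compound 2, so no measured step matches it exactly. A modest fall in the number is therefore expected, a 2.8-fold lower number from compound 3 to compound 4 (0.45 log units; beyond the scatter), with wide uncertainty. Compound 4 is estimated at 13000 nM, in the range 5000 nM to 32000 nM.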

Compound 4, concentration for 50% growth inhibition: 20200 nM
Compound 4: middle estimate off by 1.6-fold (0.19 log units), on the low side; measured number inside the range.
By their numbers in this assay, from the lowest: compound 2; then compounds 4, 1 and 3 (each within the scatter of the next).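

In this assay, the 4-methoxyphenyl on the aromatic nitrogen cannot be told apart from the 3-nitrophenyl or the 2-chlorophenyl, with a 1.8-fold lower number from compound 3 to compound 4 (0.26 log units; within the scatter) and a 1.2-fold lower number from compound 1 to compound 4 (0.06 log units; within the scatter) as the two steps. Only a 2.3-fold higher number from compound 2 to compound 4 (0.36 log units; beyond the scatter) is beyond the scatter, so compound 2, with its 3-methylphenyl, now stands apart from all three others, and losing the nitro group did not by itself bring compound 4 level with compound 2. Nothing available explains why compound 2 stands apart.

Compound 2 and compound 4 differ in both the group and its place on the aryl ring, so the compounds shown do not separate these two changes. They also leave open how an amine or a carboxylic acid on this aryl ring would read.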